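The source may hold more compounds than are shown below. What is called first, only, known or untested is meant among the compounds shown, and "the series" means these compounds.

Compound 1 `Nc1ccc(S(=O)(=O)N2CCN(c3ncc(C(O)(C(F)(F)F)C(F)(F)F)cc3C#CCO)CC2)cn1` gives 65 mL.min-1.g-1 in an ADME assay (liver) for metabolic stability, with Liver microsome (Rattus norvegicus) as the target, using microsomes and NADPH, with a stated time of 30 min, tested at 1 uM (a higher number here means faster removal of the compound, a lower number slower removal), the second highest of the three numbers shown. Compound 2 `Nc1ccc(S(=O)(=O)N2CCN(c3ncc(C(O)(C(F)(F)F)C(F)(F)F)cc3C#CCCO)CC2)cn1` gives 68 mL.min-1.g-1, and compound 3 `Nc1ccc(S(=O)(=O)N2CCN(c3ncc(C(O)(C(F)(F)F)C(F)(F)F)cc3-c3cccnc3)CC2)cn1` gives 20 mL.min-1.g-1. The step of a 1.0-fold higher number from compound 1 to compound 2 (0.02 log units; within the scatter) lies within the scatter, whereas a 3.3-fold lower number from compound 1 to compound 3 (0.51 log units; beyond the scatter) and a 3.4-fold lower number from compound 2 to compound 3 (0.53 log units; beyond the scatter) are modest steps beyond it. Compound 4 `Cc1ccc(-c2cc(C(O)(C(F)(F)F)C(F)(F)F)cnc2N2CCN(S(=O)(=O)c3ccc(N)nc3)CC2)cn1` differs from compound 1 by 6-methylpyridin-3-yl in place of 3-hydroxyprop-1-yn-1-yl on an aromatic carbon. Within the data shown here, this change closely resembles the one that gave compound 3, and those two steps are the ones that bear on it. The step to compound 4 is therefore expected to be a 3.0-fold lower number from compound 1 to compound 4 (0.47 log units; beyond the scatter), a lowering of similar size, because a 3.3-fold lower number from compound 1 to compound 3 (0.51 log units; beyond the scatter) went that way. Compound 4 is estimated at 22 mL.min-1.g-1, within a range from 11 mL.min-1.g-1 to 45 mL.min-1.g-1.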

Compound 4, intrinsic clearance in microsomes: 182 mL.min-1.g-1
The estimate for compound 4 lay 8.3-fold (0.92 log units) below the measured number; the measured number lies above the stated range.
By their numbers in this assay, from the lowest: compound 3; then compounds 1 and 2 (each within the scatter of the next); then compound 4.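

In this assay, the outcome at this aromatic carbon depends on more than placing an aromatic ring there: methyl in place of hydrogen on the pyridin-3-yl group alone gives a 9.1-fold higher number from compound 3 to compound 4 (0.96 log units; beyond the scatter). Set against the alkynyl compounds, 6-methylpyridin-3-yl therefore reverses the direction seen with pyridin-3-yl, giving a 2.8-fold higher number from compound 1 to compound 4 (0.45 log units; beyond the scatter) and a 2.7-fold higher number from compound 2 to compound 4 (0.43 log units; beyond the scatter). Nothing given here accounts for this reversal. The compounds shown leave open whether the rise is particular to methyl, or whether ethyl, methoxy, fluorine or an amine in its place would do the same.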